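The source may report more compounds than this note shows. Statements on the series, on what has been measured and on what is new or still open speak of the compounds shown alone.

Measured in a functional assay on SK-BR-3 cells (Homo sapiens) for antiproliferative activity, read by MTT assay, with a stated time of 72 h; a lower number here means a stronger inhibitor, a higher number a weaker inhibitor:
Compound 1 `CCc1ccc(C(=O)Nc2ccc3nc(N4CCN(CC)CC4)cc(C)c3c2)cc1` gives 9850 nM.
Compound 2 `CCN1CCN(c2cc(C)c3cc(NC(=O)c4ccccc4OC)ccc3n2)CC1` gives 15700 nM.
Compound 3 `Cc1cc(N2CCN(C)CC2)nc2ccc(NC(=O)c3ccc(Cl)c(Cl)c3)cc12` gives 6320 nM.

Compound 1 stands second highest of these three numbers, yet its gaps to compound 3 and to compound 2 both lie within the scatter, so no order among the three can be read. Compound 4 `CCN1CCN(c2cc(C)c3cc(NC(=O)c4ccccc4Br)ccc3n2)CC1` differs from compound 1 in one place: 2-bromophenyl in place of 4-ethylphenyl on a carbonyl carbon. Going by the values given here, one measured step bears on this change, also made on the carbonyl carbon: a 1.6-fold higher number from compound 1 to compound 2 (0.20 log units; within the scatter), a step that stayed within the scatter. Among the compounds with values here, no measured pair shows a bromine. Compound 4 is therefore expected to remain close to compound 1. The expected step is a 1.2-fold higher number from compound 1 to compound 4 (0.09 log units; within the scatter). Compound 4 is estimated at 12000 nM, with a range from 5000 nM to 30000 nM.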

Compound 4, half-maximal inhibitory concentration: 39200 nM
Compound 4: middle estimate off by 3.3-fold (0.51 log units), on the low side; measured number outside the range, above it.
By their numbers in this assay, from the lowest: compounds 3, 1 and 2 (each within the scatter of the next, the first and the last beyond it); then compound 4.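

On the carbonyl carbon, the change to 2-bromophenyl gives a 4.0-fold higher number from compound 1 to compound 4 (0.60 log units; beyond the scatter) and so moves the number beyond the scatter, which the change to 2-methoxyphenyl did not do. Bromo in place of methoxy on an aromatic carbon gives a 2.5-fold higher number from compound 2 to compound 4 (0.40 log units; beyond the scatter) and thus separates these two groups at this place. Nothing shown here accounts for either step. The compounds shown leave open how a fluoro, a hydroxyl or an aminomethyl group would read at this place. They also leave open whether bromo would give a similar step on another phenyl position.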